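Adding one more hydroxy to compound 3

The source may report more compounds than this note shows. Statements on the series, on what has been measured and on what is new or still open speak of the compounds shown alone.

- compound 1 `O=C(N/N=C/c1cccc(O)c1O)c1ccc2ccccc2n1` gives 99600 nM
- compound 2 `O=C(N/N=C/c1cccc(O)c1O)c1ccnc2ccccc12` gives 47500 nM
- compound 3 `O=C(N/N=C/c1ccc(O)cc1O)c1ccnc2ccccc12` gives 34500 nM

In an ADME assay on U-937 cells (Homo sapiens) for cytotoxicity, read by MTT assay, with a stated time of 72 h (on this read-out higher numbers stand for lower toxicity in this test and lower numbers for higher toxicity in this test), compound 3 (34500 nM) lies within the usual scatter of compound 2, while compound 1 reads higher, beyond that scatter. Compound 4 `O=C(N/N=C/c1ccc(O)c(O)c1O)c1ccnc2ccccc12` differs from compound 3 at one place: hydroxy in place of hydrogen on an aromatic carbon, ortho to two hydroxy groups and meta to a large group hydroxy in place of hydrogen on an aromatic carbon here. Among the compounds with values here, no measured pair shows this change, so any forecast stays loose. A modest move towards a lower number is expected, perhaps none beyond the scatter. The estimated move is a 1.4-fold lower number from compound 3 to compound 4 (0.14 log units; within the scatter) in this assay overall. For compound 4 the estimate is 25000 nM with 9000 nM to 60000 nM as the expected range.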

Compound 4, concentration lethal to 50% of the cells: 347000 nM
The estimate for compound 4 lay 14-fold (1.14 log units) below the measured number; the whole stated range lies below it.
By their numbers in this assay, from the lowest: compounds 3 and 2 (each within the scatter of the next); then compound 1; then compound 4.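

In this assay the added hydroxy, ortho to two hydroxy groups and meta to a large group, gives a 10-fold higher number from compound 3 to compound 4 (1.00 log units; beyond the scatter) and, by the same kind of swap, a 7.3-fold higher number from compound 2 to compound 4 (0.86 log units; beyond the scatter). So one hydroxy at this aromatic carbon can move the number beyond the scatter towards lower toxicity in this test, which compound 1, compound 2 and compound 3 could not show. Nothing measured here explains this shift. On these data alone, whether a methoxy group or an amine at this carbon would do the same remains open. So does whether this hydroxy counts alone or only together with the other two.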